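The source may hold more compounds than are shown below. What is called first, only, known or untested is meant among the compounds shown, and "the series" means these compounds.

Measured so far: compound 1 `CSC[C@H](NC(C)=O)C(=O)CCl` gives 80800 nM in a functional assay on MOLT-3 cells (Homo sapiens); a higher number here means a weaker inhibitor, a lower number a stronger inhibitor; compound 2 `CCSC[C@H](NC(C)=O)C(=O)CCl` gives 99900 nM; compound 3 `CCCCCCCCCCCCCCSC[C@H](NC(C)=O)C(=O)CCl` gives 8800 nM.

The step from compound 1 to compound 2 is methyl in place of hydrogen on a saturated chain carbon bound to a sulfur, and it made a 1.2-fold higher number from compound 1 to compound 2 (0.09 log units; within the scatter). The difference between the core of compound 1 and the core of compound 3 is not broken down here; compound 3 stands lowest of the three numbers, beyond the scatter from the other two.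

Compound 4 `CCCCCCCCCCCCCCCSC[C@H](NC(C)=O)C(=O)CCl` has not yet been measured. It differs from compound 3 by methyl in place of hydrogen on a saturated chain carbon, ten or more bonds along the chain from a sulfur. This is the same kind of change as that from compound 1 to compound 2, but at a different place, as the two differences show. Because the earlier step was a 1.2-fold higher number from compound 1 to compound 2 (0.09 log units; within the scatter), the step from compound 3 to compound 4 in this assay is expected to be small as well, around a 1.2-fold lower number from compound 3 to compound 4 (0.07 log units; within the scatter). Compound 4 is estimated at 7500 nM, between 3000 nM and 20000 nM.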

Compound 4, half-maximal inhibitory concentration: 8600 nM
Estimate against measurement, compound 4: 1.1-fold (0.06 log units) below, and the stated range covers the measured number.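

The change of methyl in place of hydrogen on a saturated chain carbon, ten or more bonds along the chain from a sulfur, made a 1.0-fold lower number from compound 3 to compound 4 (0.01 log units; within the scatter) in this assay on the core of compound 3. Set beside the same kind of change on the core of compound 1, the step does not differ: the same change on two cores in this assay, a 1.2-fold higher number (0.09 log units; within the scatter) from compound 1 to compound 2 and a 1.0-fold lower number (0.01 log units; within the scatter) from compound 3 to compound 4, 1.3-fold (0.10 log units) apart, within the scatter of two such steps. Going by these compounds alone, this shows that the change left the number within the scatter on both cores, but it rests on only two pairs, at different places on the chain, and does not show that the same would hold on other cores.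

The compounds shown leave open how the numbers run for chains of a length running from that of compound 2 to that of compound 3, and for chains longer than that of compound 4. They also leave open what a chain ending in an amine or a carboxylic acid would give.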